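The compounds below may be only part of what the source reports. "The series", "measured", "known", "first", "only" and "open" are said of these compounds alone.

Measured compounds in an assay for inhibition of Fatty-acid amide hydrolase 1 (Rattus norvegicus), using a Dixon plot; on this read-out lower numbers stand for stronger inhibition and higher numbers for weaker inhibition:

compound 1 `CSCc1ccc(-c2cnc(C(=O)CCCCCCc3ccccc3)o2)nc1` gives 11.1 nM
compound 2 `CSC(=O)CCCCc1cnc(C(=O)CCCCCCc2ccccc2)o1` gives 1.8 nM
compound 3 `COCOCCCCCc1cnc(C(=O)CCCCCCc2ccccc2)o1` gives 24.1 nM

Compound 3 stands at the highest number of the three: the step from compound 1 is a 2.2-fold higher number from compound 1 to compound 3 (0.34 log units; beyond the scatter) and that from compound 2 is a 13-fold higher number from compound 2 to compound 3 (1.13 log units; beyond the scatter), both beyond the scatter. Compound 4 `O=C(CCCCCCc1ccccc1)c1ncc(CCCCCBr)o1` has not been measured. It differs from compound 3 as follows: bromo in place of methoxymethoxy on a saturated chain carbon, five bonds along the chain from an aromatic carbon. Among the compounds with values here, no measured step changes exactly this position in this way, so the direct bearing of the series is thin. The nearest comparisons are the two steps into compound 3: the replacement of a chain-borne group with a different chain-borne group in a 13-fold higher number from compound 2 to compound 3 (1.13 log units; beyond the scatter) gave a large rise, and the replacement of an aromatic group by a chain in a 2.2-fold higher number from compound 1 to compound 3 (0.34 log units; beyond the scatter) a modest rise. Both show that this end of the molecule moves this assay by more than the scatter, while the direction for a bromo in place of methoxymethoxy is not fixed by any measured pair. A step of moderate size in this assay is expected, more likely downward than upward, since compound 3 already sits at the top of the range and the replacement removes the two acceptors counted in the difference. Compound 4 is estimated at 10 nM, within 3 nM to 40 nM, which means an expected step of a 2.4-fold lower number from compound 3 to compound 4 (0.38 log units; beyond the scatter).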

Compound 4, inhibition constant: 6.1 nM
Compound 4: middle estimate off by 1.6-fold (0.21 log units), on the high side, and the stated range covers the measured number.
By their numbers in this assay, from the lowest: compound 2; then compounds 4 and 1 (each within the scatter of the next); then compound 3.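

In this assay, within the data shown here, bromo in place of methoxymethoxy on a saturated chain carbon, five bonds along the chain from an aromatic carbon, gives a 4.0-fold lower number from compound 3 to compound 4 (0.60 log units; beyond the scatter), the first direct reading of this change at this position and one that places the bromo compound on the lower side of the methoxymethoxy compound. Losing the methoxymethoxy does not by itself reach the level of the thioester-bearing chain, as bromomethyl in place of (methylsulfanyl)carbonyl gives a 3.4-fold higher number from compound 2 to compound 4 (0.53 log units; beyond the scatter), while a 1.8-fold lower number from compound 1 to compound 4 (0.26 log units; within the scatter) leaves the bromo chain and the aromatic group of compound 1 within the scatter of each other. No supporting evidence bears on why this change moves the number.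

The compounds shown leave open how a hydroxyl, an amine or a carboxylic acid would read at this same chain carbon, and whether chloro or iodo would follow bromo. They also do not separate the departure of the methoxymethoxy from the arrival of the bromine, and a longer chain carrying bromo remains unplaced.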